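The source may report more compounds than this note shows. Statements on the series, on what has been measured and on what is new or still open speak of the compounds shown alone.

Of the compounds shown here, three of one shared core have so far been tested in an assay on PMNL cells for inhibition of Polyunsaturated fatty acid 5-lipoxygenase (Homo sapiens), read by HPLC, with stated times of 15 min and 10 min; on this read-out higher numbers stand for weaker inhibition and lower numbers for stronger inhibition. Compound 1 `COc1ccc(/C=C2\SC(c3ccc4ccccc4c3)=NC2=O)cc1` gives 80 nM in this assay, the lowest of the three numbers. Compound 2 `COc1ccc(/C=C2\SC(c3ccc(Cl)cc3)=NC2=O)c2ccccc12` gives 130 nM in this assay, a number that sits within the usual scatter of the value for compound 1, so the two cannot be told apart. Compound 3 `COc1ccc(/C=C2\SC(c3ccc(F)cc3)=NC2=O)cc1` gives 550 nM in this assay, which lies beyond the scatter and therefore marks clearly weaker inhibition than compound 1.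

Compound 4 `O=C1N=C(c2ccc3ccccc3c2)S/C1=C\c1ccc(Oc2ccccc2)cc1` has not yet been measured. It differs from compound 1 in one place: phenyl in place of methyl on an oxygen on an aromatic ring. Among the compounds with values here, none of the measured compounds differ from one another in this single place, so there is no measured step to show what such an exchange does here; the expectation must rest on compound 1 alone and on the fact that the rest of the structure is unchanged. A larger group enters at an oxygen, and without a precedent the safest guess is a step of modest size, with the direction left open. The expected step of a 1.5-fold higher number from compound 1 to compound 4 (0.18 log units; within the scatter) is thus a small one that could fall either way. Compound 4 is estimated at 120 nM, with a range from 40 nM to 400 nM.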

Compound 4, half-maximal inhibitory concentration: 60 nM
Estimate against measurement, compound 4: 2.0-fold (0.30 log units) above, and the stated range covers the measured number.
By their numbers in this assay, from the lowest: compounds 4, 1 and 2 (each within the scatter of the next, the first and the last beyond it); then compound 3.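

In this assay, replacing methyl with phenyl on the oxygen gives a 1.3-fold lower number from compound 1 to compound 4 (0.12 log units; within the scatter) and so leaves the two compounds indistinguishable. Within the data shown here, this is the first measured change at this place, and it shows that a six-membered aromatic ring of carbon can stand where compound 1 has only a methyl without any clear loss of inhibition, while the rest of the structure stays the same. No measurement shown here explains why the larger group leaves the read-out within the scatter, and this single pair gives no basis for assigning a cause.

As far as these compounds go, a single exchange cannot show how much further this place can be changed, so it remains open whether a benzyl group, a longer chain, or a chain ending in an amine or a carboxylic acid would also fit on this oxygen. It is also unknown whether methoxy to phenoxy would give a similarly small step on a different background, such as the one carrying the fluorine-substituted ring in compound 3.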